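This account rests on a few compounds, and the source may have more. Where it says the series, first, only, none or still open, it means among the compounds named here.

Three compounds that share one core and differ only in the five-membered aromatic ring have been measured in a functional assay on A-375 cells (Homo sapiens) for antiproliferative activity (on this read-out lower numbers stand for stronger inhibition and higher numbers for weaker inhibition), so far. Compound 1 `O=C(Nc1ccc(-c2cscn2)cc1)C1CCCN(Cc2ccc(F)c(F)c2)C1` gives 880 nM there, compound 2 `O=C(Nc1ccc(-c2nccs2)cc1)C1CCCN(Cc2ccc(F)c(F)c2)C1` gives 240 nM and compound 3 `O=C(Nc1ccc(-c2ccsc2)cc1)C1CCCN(Cc2ccc(F)c(F)c2)C1` gives 950 nM in the same test. Compound 3 stands at the weak end of this short series, together with compound 1. Two steps place it: there is a 1.1-fold higher number from compound 1 to compound 3 (0.03 log units; within the scatter) so that the pair cannot be told apart, and there is a 4.0-fold higher number from compound 2 to compound 3 (0.60 log units; beyond the scatter) so that only the 1,3-thiazol-2-yl member stands clear.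

Compound 4 `O=C(Nc1ccc(-c2cccs2)cc1)C1CCCN(Cc2ccc(F)c(F)c2)C1` has thiophen-2-yl in place of thiophen-3-yl on an aromatic carbon, para to a large group, and the count reads thiophen-2-yl in place of thiophen-3-yl on an aromatic carbon for this change. The nearest measured parallel is a 3.7-fold lower number from compound 1 to compound 2 (0.56 log units; beyond the scatter) where 1,3-thiazol-2-yl replaces 1,3-thiazol-4-yl in the same place. Within the data shown here, no pair of thiophenes has been measured, so this parallel is only a guide. A step of similar or slightly smaller size towards a lower number is therefore expected in this assay for this change. The estimated step is a 3.2-fold lower number from compound 3 to compound 4 (0.50 log units; beyond the scatter) on that reasoning. Compound 4 is expected at about 300 nM with an estimated range from 120 nM to 750 nM in this test.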

Compound 4, half-maximal inhibitory concentration: 390 nM
Compound 4: middle estimate off by 1.3-fold (0.11 log units), on the low side; low and high end bracket the measured number.
By their numbers in this assay, from the lowest: compounds 2 and 4 (each within the scatter of the next); then compounds 1 and 3 (each within the scatter of the next).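

In this assay, moving the attachment point of the same thiophene ring on the aromatic carbon, para to a large group, is enough by itself to shift the result, with a 2.4-fold lower number from compound 3 to compound 4 (0.39 log units; beyond the scatter), so the effect seen earlier between two thiazole rings now has a counterpart in a second ring type. Thiophen-2-yl and 1,3-thiazol-2-yl cannot be told apart, with a 1.6-fold higher number from compound 2 to compound 4 (0.21 log units; within the scatter), while thiophen-2-yl stands clear of 1,3-thiazol-4-yl, with a 2.3-fold lower number from compound 1 to compound 4 (0.35 log units; beyond the scatter), so among these four compounds the two rings joined through their 2-position form one group, apart from the other two, and no compound goes against this. Nothing available here explains why the attachment point matters in this way.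

As far as these compounds go, it remains open whether the same pattern extends to other five-membered rings, such as furan-2-yl or furan-3-yl, or to a six-membered pyridin-2-yl ring. From the compounds shown here alone, how a methyl group or an amine on the thiophen-2-yl ring would shift the number in this assay also remains open.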